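Methoxy for fluoro on a benzothiazole-linked anilide series

The compounds below may be only part of what the source reports. "The series", "measured", "known", "first", "only" and "open" are said of these compounds alone.

Measured compounds:
compound 1 `O=C(CCC(=O)c1ccccc1)Nc1nc2ccc(F)cc2s1` gives 300 mg/kg
compound 2 `COc1ccc2nc(NC(=O)CCC(=O)c3ccccc3)sc2c1` gives 30 mg/kg
compound 3 `O=C(Nc1nc2ccc(F)cc2s1)c1ccccc1C(=O)c1ccccc1` gives 100 mg/kg

In a functional assay on the whole organism with Mus musculus as the target, in the maximal electroshock model, with a stated time of 4 h (on this read-out lower numbers stand for an effect already at smaller amounts and higher numbers for an effect only at larger amounts of compound), compound 1 gives 300 mg/kg, and compound 2 gives 30 mg/kg. The change between them, (methoxy in place of fluoro on an aromatic carbon), made the step of a 10-fold lower number from compound 1 to compound 2 (1.00 log units; beyond the scatter). Compound 3 gives 100 mg/kg; how its core differs from that of compound 1 is not broken down here. Compound 4 `COc1ccc2nc(NC(=O)c3ccccc3C(=O)c3ccccc3)sc2c1` is not yet measured. It arises from compound 3 by methoxy in place of fluoro on an aromatic carbon, the same change as from compound 1 to compound 2, at the same place. Going by the values given here, on the strength of the single earlier step of a 10-fold lower number from compound 1 to compound 2 (1.00 log units; beyond the scatter), compound 4 is expected to give a lower number than compound 3, though a second example of a change rarely repeats the first in full size, so a step of a 3.3-fold lower number from compound 3 to compound 4 (0.52 log units; beyond the scatter) is estimated. Compound 4 is therefore expected at about 30 mg/kg, between 10 mg/kg and 100 mg/kg.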

Compound 4, minimum effective dose: 100 mg/kg
Beside the measured number, compound 4's estimate is 3.3-fold (0.52 log units) below it; measured number inside the range.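

In this assay, methoxy in place of fluoro on an aromatic carbon gives no change at the digits printed from compound 3 to compound 4 (within the scatter). Set beside the earlier step, the same change did not carry over in size from one core to the other: the same change on two cores in this assay, a 10-fold lower number (1.00 log units; beyond the scatter) from compound 1 to compound 2 and no change at the digits printed (within the scatter) from compound 3 to compound 4, 10-fold (1.00 log units) apart, beyond the scatter of two such steps This shows that the lower number seen on the core of compound 1 cannot be assumed on the core of compound 3, but with a single pair on each core it does not show which difference between the cores matters or how the change would behave on a third core.

The compounds shown leave open how an amine or an ethoxy group at the same place would behave on these two cores. They also leave open whether a longer chain in the amide part would alter the size of the step.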